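Moving the chlorine on the anilide ring: compound 1 to compound 4

This account rests on a few compounds, and the source may have more. Where it says the series, first, only, none or still open, it means among the compounds named here.

Within the data shown here, the three compounds measured so far share one core and differ in the chain and in the aryl group carried on the amide nitrogen. Compound 1 `Cn1c(Cc2nn(C)c(=O)c3ccccc23)nnc1SCCCCCCCCCCC(=O)Nc1ccccc1Cl` was tested in an assay on isolated protein (Mus musculus) for inhibition of IL15-IL15 receptor (Homo sapiens), read by resazurin assay, with stated times of 30 min and 2.5 days (on this read-out higher numbers stand for weaker inhibition and lower numbers for stronger inhibition), where compound 1 gives 15000 nM. Compound 2 `Cn1c(Cc2nn(C)c(=O)c3ccccc23)nnc1SCCCCCCCC(=O)Nc1ccc(O)cc1O` in this assay gives 17000 nM, and compound 3 `CC(C)COc1ccc(NC(=O)CSc2nnc(Cc3nn(C)c(=O)c4ccccc34)n2C)cc1` gives 30000 nM. Compound 1 shows the lowest of the three numbers, but the gaps from compound 1 to compound 2 and to compound 3 both fall within the usual scatter of repeated measurements, so the three compounds cannot be told apart on this read-out.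

Compound 4 `Cn1c(Cc2nn(C)c(=O)c3ccccc23)nnc1SCCCCCCCCCCC(=O)Nc1ccc(Cl)cc1` has not yet been measured in this assay. It is compound 1 with the same atoms joined differently: 4-chlorophenyl in place of 2-chlorophenyl on an amide-type nitrogen. The change keeps the chain and the chlorine, and only the position of the chlorine on the phenyl ring carried by the amide nitrogen is altered.

Among the measured compounds shown here, with no single-change step between measured compounds to lean on, and with all three measured numbers so close together, the step from compound 1 to compound 4 is expected to be small, most likely none beyond the scatter, with no change at the digits printed from compound 1 to compound 4 (within the scatter) as the expected shift. Compound 4 is therefore estimated at 15000 nM in this assay, within a range from 6000 nM to 40000 nM.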

Compound 4, half-maximal inhibitory concentration: 20000 nM
Compound 4: the middle estimate sits 1.3-fold (0.12 log units) below what was measured; low and high end bracket the measured number.
By their numbers in this assay, from the lowest: compounds 1, 2, 4 and 3 (each within the scatter of the next).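

Among these compounds, the pair gives the first step that changes one place only: in this assay, 4-chlorophenyl in place of 2-chlorophenyl on an amide-type nitrogen gives a 1.3-fold higher number from compound 1 to compound 4 (0.12 log units; within the scatter) and leaves the two compounds indistinguishable on this read-out. Compound 2 and compound 3 differ from compound 1 in the chain and in the aryl group at once, and could not speak to the position of the chlorine alone, whereas this pair holds the chain and the chlorine fixed. Nothing available here explains why the two placements of the chlorine cannot be told apart.

On these data alone, what stays open is whether a different group on this phenyl ring, such as an amine, a carboxylic acid or a nitrile, would give a step beyond the scatter with the chain of compound 1 kept in place. Also open, as far as these compounds go, is what the chain contributes by itself, which a longer chain or a shorter chain carrying the same 2-chlorophenyl amide would show as a single change.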